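This account rests on a few compounds, and the source may have more. Where it says the series, first, only, none or still open, it means among the compounds named here.

Compound 1 `Nc1ccc(-c2ccc3ncc(-c4nnco4)c(NCCCn4ccnc4)c3c2)cc1` gives 24 nM in an assay on Sf9 cells for inhibition of DNA topoisomerase 1 (Homo sapiens), in phosphate buffer, with a stated time of 30 min; on this read-out lower numbers stand for stronger inhibition and higher numbers for weaker inhibition. Compound 2 `COc1ccc(-c2ccc3ncc(-c4nnco4)c(NCCCn4cccc4)c3c2)cc1` gives > 10000 nM in this assay, which is a limit of the assay and not a number.

Compound 2 therefore stands at the weak end of what has been measured, its result given only as a limit; compound 1 sits well within the measurable range. For the measured compounds named here, the two differ in more than one place, so no single step between them is counted, and their two values are reported only as they stand, with the limit of > 10000 nM in this assay, at which 1 of the 2 values shown sits, describing where compound 2 sits.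

Compound 3 `COc1ccc(-c2ccc3ncc(-c4nnco4)c(NCCCN4CCCC4)c3c2)cc1` has not yet been measured in this assay. It differs from compound 2 by one change: pyrrolidin-1-yl in place of 1H-pyrrol-1-yl on a saturated chain carbon, three bonds along the chain from a nitrogen on an aromatic ring. Going by the values given here, no measured pair shows this change, so the size of the step rests on expectation alone. The account expects the step from compound 2 to compound 3 to be an at least 16-fold lower number from compound 2 to compound 3 (1.22 log units; beyond the scatter), towards stronger inhibition, though a limit remains possible. Compound 3 is estimated at 600 nM, between 50 nM and 10000 nM.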

Compound 3, half-maximal inhibitory concentration: > 10000 nM
Compound 3 ended at the assay's limit (the forecaster's own chance of this, stated with the estimate: 30%); at least 16-fold (1.22 log units) between middle value and limit.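

Compound 3, like compound 2, ends at a limit of this assay and not at a number, so the change from 1H-pyrrol-1-yl to pyrrolidin-1-yl gives no step that can be read: the limit of > 10000 nM in this assay, at which 2 of the 3 values shown sit.

The compounds shown leave open how far either compound lies past that limit, and whether the two groups would differ on a compound with a measurable value.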